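Swapping a chlorophenyl for a pyrimidine on the core

The compounds below may be only part of what the source reports. "The series", "measured", "known", "first", "only" and "open" are said of these compounds alone.

Compound 1 `Cc1nc2c(cnn2CC2CCCCC2)c(=O)n1-c1ccc(Cl)cc1`: > 100000 nM, a limit of the assay.
Compound 2 `Cc1nc2c(cnn2-c2cccc(Cl)c2)c(=O)n1-c1ccc(Cl)cc1`: 220 nM.

Going by the values given here, in an in vitro functional assay on cells for antagonist activity at metabotropic glutamate receptor 1 (Homo sapiens), read by FLIPR and calcium flux (a lower number here means a stronger inhibitor, a higher number a weaker inhibitor), compound 2 gives the only full number here, 220 nM. Compound 1 reaches only the limit (the limit of > 100000 nM in this assay, at which 1 of the 2 values shown sits). Among the compounds with values here, the single measured step, an at least 450-fold lower number from compound 1 to compound 2 (2.65 log units; beyond the scatter), was large. Compound 3 `Cc1nc2c(cnn2-c2cncnc2)c(=O)n1-c1ccc(Cl)cc1` differs from compound 2 by pyrimidin-5-yl in place of 3-chlorophenyl on an aromatic nitrogen. An aromatic six-membered ring stays on the same nitrogen, so a far smaller change than the measured step is expected, leaning toward a weaker number. Compound 3 is therefore estimated at 2000 nM, between 400 nM and 20000 nM. That amounts to an expected step of a 9.1-fold higher number from compound 2 to compound 3 (0.96 log units; beyond the scatter).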

Compound 3, half-maximal inhibitory concentration: 9800 nM
Estimate against measurement, compound 3: 4.9-fold (0.69 log units) below, within the range that was stated.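

An aromatic six-membered ring on this nitrogen does not by itself keep the activity: pyrimidin-5-yl in place of 3-chlorophenyl gives a 45-fold higher number from compound 2 to compound 3 (1.65 log units; beyond the scatter). Even so, pyrimidin-5-yl still does better than cyclohexylmethyl, with an at least 10-fold lower number from compound 1 to compound 3 (1.00 log units; beyond the scatter). That step is only a bound, as compound 1 stands at a limit and not at a number: the limit of > 100000 nM in this assay, at which 1 of the 3 values shown sits.

The swap removes the chlorine and brings in two ring nitrogens at once, and the compounds shown cannot separate these two changes. On these data alone, whether an unsubstituted phenyl or a pyridin-3-yl group on this nitrogen would fall nearer compound 2 or compound 3 stays open.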